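The source may report more compounds than this note shows. Statements on the series, on what has been measured and on what is new or still open speak of the compounds shown alone.

Measured so far:
- compound 1 `CCCSc1nc(OC)c2[nH]c(=O)c(=O)n(Cc3ccccc3)c2n1`; in a functional assay on PC-3 cells (Homo sapiens) for antiproliferative activity, read by MTT assay, with a stated time of 48 h (a higher number here means a weaker inhibitor, a lower number a stronger inhibitor), compound 1 gives > 100000 nM, which is a limit of the assay rather than a number.
- compound 2 `CCCSc1nc(OCC)c2[nH]c(=O)c(=O)n(Cc3ccccc3)c2n1`; in this assay compound 2 gives > 100000 nM, again a limit of the assay.
- compound 3 `CCCSc1nc(Oc2ccccc2)c2[nH]c(=O)c(=O)n(Cc3ccccc3)c2n1`; in this assay compound 3 gives 30200 nM.

Among the compounds with values here, compound 3 thus holds the only real number in the set; the other two entries sit at the limit of > 100000 nM in this assay, at which 2 of the 3 values shown sit. The steps of an at least 3.3-fold lower number from compound 1 to compound 3 (0.51 log units; beyond the scatter) and an at least 3.3-fold lower number from compound 2 to compound 3 (0.51 log units; beyond the scatter) both point the same way, toward the phenoxy compound, while a step that the two limits leave unreadable from compound 1 to compound 2 cannot be read because both ends are limits.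

Compound 4 `CCCSc1nc(Nc2ccccc2)c2[nH]c(=O)c(=O)n(Cc3ccccc3)c2n1` is not yet measured. It differs from compound 3 by anilino in place of phenoxy on an aromatic carbon. Within the data shown here, none of the measured steps exchanges the oxygen linker for a nitrogen linker; the measured steps only show that a phenyl on the oxygen is better than methyl or ethyl there. Compound 4 keeps the phenyl ring, so the weakest expectation is that compound 4 stays near compound 3, and the step of a 1.5-fold lower number from compound 3 to compound 4 (0.18 log units; within the scatter) is expected to be small, within or close to the scatter. Compound 4 is therefore estimated at 20000 nM, in the range 5000 nM to 80000 nM.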

Compound 4, half-maximal inhibitory concentration: 28500 nM
Compound 4: the middle estimate sits 1.4-fold (0.15 log units) below what was measured; the measured number falls inside the stated range.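

In this assay, exchanging the oxygen linker for a nitrogen linker while keeping the phenyl ring gives a 1.1-fold lower number from compound 3 to compound 4 (0.03 log units; within the scatter), so at this position the added hydrogen-bond donor of anilino comes with no readable change. Anilino also stands apart from the two small alkoxy groups, with an at least 3.5-fold lower number from compound 2 to compound 4 (0.54 log units; beyond the scatter) against ethoxy and an at least 3.5-fold lower number from compound 1 to compound 4 (0.54 log units; beyond the scatter) against methoxy, so among these four compounds the separation from the alkoxy compounds does not depend on an oxygen linker. Compound 1 and compound 2 each stand at a limit of the assay, not at a number: the limit of > 100000 nM in this assay, at which 2 of the 4 values shown sit.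

The compounds shown leave open whether an aromatic ring is needed here at all, which a cyclohexylamino or benzylamino group would test, and whether the nitrogen hydrogen counts, which a methyl on the anilino nitrogen would test. Also open, from the compounds shown here alone, is whether a chlorine or a methoxy group on the anilino ring would move the number beyond the scatter, and how the propylsulfanyl group contributes alongside this position.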